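The source may hold more compounds than are shown below. What is called first, only, known or untested is meant among the compounds shown, and "the series" means these compounds.

Compound 1 `N#CC1=C(NCC(=O)O)N(c2ccccc2)C(=O)N2CCCCC(N3CCCC3)C12` was tested in a functional assay on the whole organism (strain albino) for inhibition, with Rattus norvegicus as the target, read by paw edema, with stated times of 1 h and 3 h, at a dose of 24 mmol/kg by the intraperitoneal route (a higher number here means a stronger effect of the compound at the dose given, a lower number a weaker effect), where compound 1 gives 91.4%, the lowest of the three numbers shown, though the two others lie within the usual scatter of it. Compound 2 `N#Cc1c2n(c(=O)n(-c3ccccc3)c1=N)CCCCC2N1CCCC1` gives 94.2%, and compound 3 `CCOC(=O)C(=O)NC1=C(C#N)C2C(N3CCCC3)CCCCN2C(=O)N1c1ccccc1` gives 92.4%. Among the measured compounds shown here, the one measured step that changes a single place is a number 1 percentage points higher from compound 1 to compound 3 (within the scatter). Compound 4 `COC(=O)C(=O)NC1=C(C#N)C2C(N3CCCC3)CCCCN2C(=O)N1c1ccccc1` differs from compound 1 in the same way: (methoxycarbonyl)carbonyl in place of carboxymethyl on an amine nitrogen. For the measured compounds named here, that step is the only one bearing on this change, and it was within the scatter, so for compound 4 a step of about a number 0.6 percentage points higher from compound 1 to compound 4 (within the scatter) is expected, with no change beyond the scatter. Compound 4 is therefore estimated at 92%, between 84% and 97.5%.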

Compound 4, a percentage reported as inhibition, in the whole organism at one dose (the size of the read-out at that dose, not a potency): 89.8%
Estimate against measurement, compound 4: 2.2 percentage points above; the measured number falls inside the stated range.
By their numbers in this assay, from the lowest: compounds 4, 1, 3 and 2 (each within the scatter of the next).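

In this assay, the step of a number 1.6 percentage points lower from compound 1 to compound 4 (within the scatter) gives a second group of this kind on the amine nitrogen, after compound 3, that stays within the scatter of carboxymethyl. Going from the ethoxycarbonyl to the methoxycarbonyl group gives a number 2.6 percentage points lower from compound 3 to compound 4 (within the scatter) and so also leaves the read-out unchanged beyond the scatter, which means the ester's chain length shows no effect here. Nothing measured here explains this flat result.

Still open, going by these compounds, is whether a plain amine or a much longer chain, such as a butyl ester, on this nitrogen would move the number. Also open, on these data alone, is whether these compounds would separate at a lower dose.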